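The source may hold more compounds than are shown below. What is called first, only, known or untested is meant among the compounds shown, and "the series" means these compounds.

In a functional assay on HEK293 cells for agonist activity at Glucose-dependent insulinotropic receptor (Homo sapiens), read by cAMP accumulation, with a stated time of 30 min (a lower number here means that less compound is needed, a higher number that more compound is needed for the effect), compound 2 `CC1(OC(=O)N2CC3COCC(C2)C3Oc2ncnc(Nc3ccc(-n4cncn4)cc3F)c2F)CC1` gives 19 nM. For the measured compounds named here, compound 1 `CC1(OC(=O)N2CC3COCC(C2)C3Oc2ncnc(Oc3ccccc3F)c2F)CC1`, the only other compound measured so far, gives 26 nM in this assay, and the two values lie within the usual scatter of each other. Compound 3 `CC1(OC(=O)N2CC3COCC(C2)C3Oc2ncnc(Nc3cccnc3Cl)c2F)CC1` has not yet been measured; it differs from compound 2 by a group of 7 heavy atoms (5 carbon, 1 nitrogen, 1 chlorine; one six-membered aromatic ring with 1 hetero atom) in place of a group of 12 heavy atoms (8 carbon, 3 nitrogen, 1 fluorine; one five-membered aromatic ring with 3 hetero atoms, one six-membered aromatic ring of carbon only), on a nitrogen on an aromatic ring. Going by the values given here, no measured pair shows this change, so the only guide is that compound 1 and compound 2, with different groups at this place, give close values. A step of a 2.1-fold higher number from compound 2 to compound 3 (0.32 log units; beyond the scatter) is expected, small and, if anything, toward a higher number. In this assay compound 3 is expected to give about 40 nM, within a range from 10 nM to 160 nM.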

Compound 3, half-maximal effective concentration: 17 nM
For compound 3 the middle estimate is 2.4-fold (0.37 log units) above the measured one; the range from low to high includes it.
By their numbers in this assay, from the lowest: compounds 3, 2 and 1 (each within the scatter of the next).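

On a nitrogen on an aromatic ring, the 2-chloropyridin-3-yl group of compound 3 does as well as the larger group of compound 2 in this assay (a 1.1-fold lower number from compound 2 to compound 3 (0.05 log units; within the scatter)). Putting (2-chloropyridin-3-yl)amino in place of 2-fluorophenoxy on an aromatic carbon gives much the same picture (a 1.5-fold lower number from compound 1 to compound 3 (0.18 log units; within the scatter)), so three quite different groups at this place give close values. No measurement at hand explains this. Still open, from the compounds shown here alone, is whether a group without an aromatic ring, such as a short alkyl chain on that nitrogen, or a ring carrying a carboxylic acid, would also give a close value.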